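Trading a trifluoromethyl phenacyl ether for a methylbenzyl ether

This account rests on a few compounds, and the source may have more. Where it says the series, first, only, none or still open, it means among the compounds named here.

Of the compounds shown here, three built on one shared core have been measured. Compound 1 `COc1cc(OC)c(-c2coc3cc(OCc4ccccc4)ccc3c2=O)cc1OC` carries a benzyl group on a saturated chain carbon bound to an oxygen on an aromatic ring, and in a functional assay on HepG2 cells (Homo sapiens) for antiproliferative activity, read by MTT assay, with a stated time of 24 h (on this read-out lower numbers stand for stronger inhibition and higher numbers for weaker inhibition), compound 1 gives 1320 nM. Compound 2 `COc1ccc2c(=O)c(-c3cc(OC)c(OC)cc3OC)coc2c1` has hydrogen in that place and gives 2040 nM. Compound 3 `COc1cc(OC)c(-c2coc3cc(OCC(=O)c4cccc(C(F)(F)F)c4)ccc3c2=O)cc1OC` carries a (3-(trifluoromethyl)phenyl)carbonyl there. In this assay compound 3 gives > 10000 nM, which is a limit of the assay rather than a number. Compound 3 therefore sits at the limit of > 10000 nM in this assay, at which 1 of the 3 values shown sits, and is the weakest of the three.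

The measured steps are a 1.5-fold higher number from compound 1 to compound 2 (0.19 log units; within the scatter), an at least 7.5-fold higher number from compound 1 to compound 3 (0.87 log units; beyond the scatter) and an at least 4.9-fold higher number from compound 2 to compound 3 (0.69 log units; beyond the scatter).

Compound 4 `COc1cc(OC)c(-c2coc3cc(OCc4ccccc4C)ccc3c2=O)cc1OC` is the untested compound; its change from compound 3 is 2-methylphenyl in place of (3-(trifluoromethyl)phenyl)carbonyl on a saturated chain carbon bound to an oxygen on an aromatic ring. This largely undoes the change that took compound 1 to compound 3, leaving a benzyl-type ether close to compound 1 with a methyl added. Since the step from compound 1 to compound 3 was an at least 7.5-fold higher number from compound 1 to compound 3 (0.87 log units; beyond the scatter), a step of similar size back toward lower numbers is expected, namely an at least 6.6-fold lower number from compound 3 to compound 4 (0.82 log units; beyond the scatter). Compound 4 is estimated at 1500 nM, with a range from 600 nM to 4000 nM.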

Compound 4, half-maximal inhibitory concentration: 1860 nM
Beside the measured number, compound 4's estimate is 1.2-fold (0.09 log units) below it, and the stated range covers the measured number.
By their numbers in this assay, from the lowest: compounds 1, 4 and 2 (each within the scatter of the next). At a limit, above all of these: compound 3.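

In this assay, putting 2-methylphenyl in place of (3-(trifluoromethyl)phenyl)carbonyl on the saturated chain carbon gives an at least 5.3-fold lower number from compound 3 to compound 4 (0.73 log units; beyond the scatter), which shows that the weak result of compound 3 is not a fixed feature of substitution at this position and that a large aromatic group can stay there without that loss. Adding a methyl to the aromatic ring of the benzyl group gives a 1.4-fold higher number from compound 1 to compound 4 (0.15 log units; within the scatter), and the whole 2-methylphenyl group in place of hydrogen gives a 1.1-fold lower number from compound 2 to compound 4 (0.04 log units; within the scatter), so hydrogen, phenyl and 2-methylphenyl cannot be told apart in this assay, with compound 3 the one case that goes against this flat picture. Compound 3 remains a limit of the assay and not a number: the limit of > 10000 nM in this assay, at which 1 of the 4 values shown sits.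

The compounds shown leave open whether the carbonyl or the trifluoromethyl group accounts for the result of compound 3, as the two leave together in the change to compound 4. They also leave open how an amine, a carboxylic acid or a longer chain at this position would read in this assay.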